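The source may hold more compounds than are shown below. What is called first, only, known or untested is meant among the compounds shown, and "the series" means these compounds.

Compound 1 `COC(=O)C[C@H](NC(=O)OC(C)(C)C)C(=O)N(Cc1ccc(F)cc1)C1(C(=O)NCc2ccccc2)CCNCC1` in an ADME assay on MDCK cells (Canis lupus familiaris) for cytotoxicity, read by microscopy, with a stated time of 72 h; a higher number here means that more compound is tolerated, a lower number that less compound is tolerated: 100000 nM
Compound 2 `CC(C)(C)OC(=O)N[C@@H](CC(=O)O)C(=O)N(Cc1ccc(F)cc1)C1(C(=O)NCc2ccccc2)CCNCC1` in this assay: 79000 nM
Compound 3 `CC(C)(C)OC(=O)N[C@@H](CC(N)=O)C(=O)N(Cc1ccccc1)C1(C(=O)NCc2ccccc2)CCN(Cc2ccccc2)CC1` in this assay: a limit, > 100000 nM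

Among the two plain numbers, compound 1 has the higher one, but the step of a 1.3-fold lower number from compound 1 to compound 2 (0.10 log units; within the scatter) stays within the scatter. The result for compound 3 is a limit of this assay, not a number.

Compound 4 `COC(=O)C[C@H](NC(=O)OC(C)(C)C)C(=O)N(Cc1ccc(F)cc1)C1(C(=O)NCc2ccccc2)CCN(Cc2cccc(F)c2)CC1` differs from compound 1 by 3-fluorobenzyl in place of hydrogen on an amine nitrogen in a ring. For the measured compounds named here, no measured step touches this amine nitrogen in a ring, so the one known step does not bear on the change directly. Compound 3, which carries a benzyl on that nitrogen among other differences, sits at the limit of > 100000 nM in this assay, at which 1 of the 3 values shown sits.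

Compound 4 is expected to stay close to compound 1, with the step of a 1.3-fold lower number from compound 1 to compound 4 (0.10 log units; within the scatter) expected within the scatter. Compound 4 is estimated at 80000 nM, in the range 25000 nM to 150000 nM.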

Compound 4, minimum cytotoxic concentration: 84000 nM
Compound 4: middle estimate off by 1.1-fold (0.02 log units), on the low side; low and high end bracket the measured number.
By their numbers in this assay, from the lowest: compounds 2, 4 and 1 (each within the scatter of the next).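

Putting 3-fluorobenzyl in place of hydrogen on the amine nitrogen in a ring gives in this assay a 1.2-fold lower number from compound 1 to compound 4 (0.08 log units; within the scatter); this position therefore takes an added aromatic ring without a readable change in how much compound the cells tolerate. Compound 3 also carries a benzyl on that nitrogen, among other differences, but its result is a limit and not a number: the limit of > 100000 nM in this assay, at which 1 of the 4 values shown sits.

As far as these compounds go, whether a smaller group such as methyl, or a chain ending in an amine, would behave the same on this nitrogen remains open. Also open, from the compounds shown here alone, is whether 3-fluorobenzyl would do the same on compound 2, which carries the carboxylic acid.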